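The compounds below may be only part of what the source reports. "The series", "measured", "known", "first", "only" and "open" are said of these compounds alone.

Of the compounds shown here, three of a shared core have been measured in an assay on HEK293 cells for agonist activity at Toll-like receptor 8 (Homo sapiens), read by spectrophotometry; a higher number here means that more compound is needed for the effect, a lower number that less compound is needed. Compound 1 `CCCCNc1nc(N)nc(C)c1CCCN1C(=O)c2ccccc2C1=O` gives 453 nM. Compound 2 `CCCCNc1nc(N)nc(C)c1C` gives 3280 nM. Compound 3 `CCCCNc1nc(N)nc(C)c1C#CCN1CCCCC1` gives 3790 nM. Compound 2 thus stands second highest of the three numbers: it sits within the scatter of compound 3, so the two cannot be told apart, while compound 1 lies well beyond the scatter with a markedly lower number, meaning less of compound 1 is needed for the effect.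

Compound 4 `CCCCNc1nc(N)nc(C)c1CCCC(C)(C)O` has not yet been measured. It differs from compound 2 in one place: 3-hydroxy-3-methylbutyl in place of hydrogen on a saturated chain carbon bound to an aromatic carbon. Whether lengthening the chain at this place lowers the number is not settled by the two measured cases, since compound 1 shows a lower number than compound 2, whereas compound 3 does not. Compound 4 is therefore expected to give a moderately lower number, and the estimated step is a 4.7-fold lower number from compound 2 to compound 4 (0.67 log units; beyond the scatter). For compound 4 in this assay a value of 700 nM is expected, within a range from 150 nM to 3000 nM.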

Compound 4, half-maximal effective concentration: 1220 nM
The estimate for compound 4 lay 1.7-fold (0.24 log units) below the measured number, and the stated range covers the measured number.
By their numbers in this assay, from the lowest: compound 1; then compound 4; then compounds 2 and 3 (each within the scatter of the next).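

In this assay, putting 3-hydroxy-3-methylbutyl in place of hydrogen on a saturated chain carbon bound to an aromatic carbon gives a 2.7-fold lower number from compound 2 to compound 4 (0.43 log units; beyond the scatter). Going by these compounds alone, this is the first single change at this place that can be read as a step, and it shows that a group with no ring can bring the number down, though only modestly. Within the data shown here, nothing measured so far gives a reason for this step.

The compounds shown leave open which part of the new group matters: a plain 3-methylbutyl chain without the hydroxyl would separate the chain from the hydroxyl, and a chain ending in an amine or a carboxylic acid would show how far the end of the chain can vary. Also open is what lies behind the gap between the printed numbers of compound 4, at 1220 nM, and compound 1, at 453 nM, whose chains differ in both length and end group.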